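Replacing Methoxymethyl with 3-Methyl-1,2-oxazol-5-yl

The source may report more compounds than this note shows. Statements on the series, on what has been measured and on what is new or still open speak of the compounds shown alone.

Measured so far, in an ADME assay on HEK293 cells (Homo sapiens) for cytotoxicity, read by ATP content, with a stated time of 6 h; on this read-out higher numbers stand for lower toxicity in this test and lower numbers for higher toxicity in this test:
- Compound 1 `CCCCNc1nc(N)nc2ccn(Cc3ccsc3)c12`: only a limit, > 24000 nM
- Compound 2 `CCCCNc1nc(N)nc2ccn(Cc3cccnc3)c12`: only a limit, > 24000 nM
- Compound 3 `COCCNc1nc(N)nc2ccn(Cc3ccccn3)c12`: only a limit, > 24000 nM

Compound 3 therefore stands not at a number but at the edge of what the test can report; the same holds for the other two, as the limit of > 24000 nM in this assay, at which 3 of the 3 values shown sit, shows. The not yet measured compound 4 `Cc1cc(CNc2nc(N)nc3ccn(Cc4ccccn4)c23)on1` differs from compound 3 in one place: 3-methyl-1,2-oxazol-5-yl in place of methoxymethyl on a saturated chain carbon bound to a nitrogen on an aromatic ring. A newcomer can read this as trading a small open chain for a five-membered aromatic ring on the chain that hangs from the ring nitrogen.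

Going by the values given here, only one step between measured compounds is available, a step that the two limits leave unreadable from compound 1 to compound 2. Both its ends are limits, so its size cannot be read. It also concerns a different part of the shared core than the change to compound 4. Among the compounds with values here, no measured step thus bears directly on the present change, and the three limits together give no sign of a readable effect anywhere in this set.

The expectation for compound 4 is therefore a step of a number no higher from compound 3 to compound 4 (the limit leaves the size open), that is, no change beyond the scatter and most likely again a limit. Compound 4 is estimated at 24000 nM, between 10000 nM and 60000 nM.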

Compound 4, half-maximal cytotoxic concentration: > 24000 nM
Compound 4 was reported as a limit (the forecaster's own chance of this, stated with the estimate: 80%); the middle value sits exactly at the limit.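

Compound 3 and compound 4 both end at a limit rather than a number, so the step between them cannot be read, and the same holds for every step in this set: the limit of > 24000 nM in this assay, at which 4 of the 4 values shown sit.

The compounds shown leave open whether any change to the shared core would give an actual number in this assay, and how these compounds truly compare.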